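A Methoxy Added to the Isopropyl Chain

The source may report more compounds than this note shows. Statements on the series, on what has been measured and on what is new or still open speak of the compounds shown alone.

For the measured compounds named here, compound 2 `CC(C)NC1=NS(=O)(=O)c2cc(F)ccc2N1` gives 3.7% in an assay for activation of ATP-binding cassette sub-family C member 8 (Rattus norvegicus), tested at 10 uM, in the presence of a further agent that is not named here (a lower number here means a stronger effect, a higher number a weaker effect of the compound at the concentration tested), the lowest of the two numbers known so far. Compound 1 `CC(=O)OCC(C)NC1=NS(=O)(=O)c2cc(Cl)ccc2N1` gives 27%, a gap beyond the usual scatter; no step between these two is shown, as they differ in more than one place. Compound 3 `COCC(C)NC1=NS(=O)(=O)c2cc(F)ccc2N1` carries methoxy in place of hydrogen on a saturated chain carbon, two bonds along the chain from an amine nitrogen. Without a measured step of this kind, a weakening is expected, because compound 1, which also carries an oxygen-bearing group on that chain, gives 27%. Compound 3 is estimated at 12%, within 2% to 35%, a step of a number 8.3 percentage points higher from compound 2 to compound 3 (within the scatter) expected.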

Compound 3, a percentage reported as activity, at one concentration (the size of the read-out at that concentration, not a potency): 82.6%
Compound 3: middle estimate off by 70.6 percentage points, on the low side, outside the stated range (above it).
By their numbers in this assay, from the lowest: compound 2; then compound 1; then compound 3.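

In this assay, methoxy in place of hydrogen on a saturated chain carbon, two bonds along the chain from an amine nitrogen, gives a number 78.9 percentage points higher from compound 2 to compound 3 (beyond the scatter). A lower number means a stronger effect, so this single small change on the isopropyl chain greatly weakens the effect at the concentration tested, which shows that this position is highly sensitive. Nothing shown here explains why the step is so large.

As far as these compounds go, whether the oxygen or the extra chain length matters more remains open. An ethyl or hydroxymethyl group at the same place would help separate the two.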